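Sulfone aryl swap in the fluoroquinoline sulfone series

This account rests on a few compounds, and the source may have more. Where it says the series, first, only, none or still open, it means among the compounds named here.

Three compounds share a core: compound 1 `O=S(=O)(c1cc(Cl)cc(Cl)c1)c1cnc2c(F)cccc2c1-c1ccccc1F`, compound 2 `COc1cccc(-c2c(S(=O)(=O)c3cc(Cl)cc(Cl)c3)cnc3c(F)cccc23)c1` and compound 3 `O=S(=O)(c1cc(Cl)cc(Cl)c1)c1cnc2c(F)cccc2c1-c1cccc(F)c1`. In an ADME assay on microsomes from liver (Homo sapiens) for metabolic stability, tested at 2.5 uM (a higher number here means faster removal of the compound, a lower number slower removal), compound 1 gives 0.44 mL/min, compound 2 gives 2.31 mL/min and compound 3 gives 1.08 mL/min; compound 2 has the highest number of the three, with a 2.1-fold lower number from compound 2 to compound 3 (0.33 log units; beyond the scatter) and a 5.3-fold higher number from compound 1 to compound 2 (0.72 log units; beyond the scatter), and a 2.5-fold higher number from compound 1 to compound 3 (0.39 log units; beyond the scatter) completes the set.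

Compound 4 `COc1cccc(-c2c(S(=O)(=O)c3cccc(F)c3)cnc3c(F)cccc23)c1` differs from compound 2 by 3-fluorophenyl in place of 3,5-dichlorophenyl on a sulfonyl sulfur. Going by the values given here, all measured steps change the group on the aromatic carbon, none the group on the sulfonyl sulfur, so no step bears directly on this change. A step no larger than those seen is expected, in either direction, a 1.4-fold lower number from compound 2 to compound 4 (0.16 log units; within the scatter). Compound 4 is therefore estimated at 1.6 mL/min, within 0.7 mL/min to 3.5 mL/min.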

Compound 4, intrinsic clearance in a liver preparation (reported as CLH), per the amount of preparation that the assay uses: 2.6 mL/min
Beside the measured number, compound 4's estimate is 1.6-fold (0.21 log units) below it; the measured number falls inside the stated range.
By their numbers in this assay, from the lowest: compound 1; then compound 3; then compounds 2 and 4 (each within the scatter of the next).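

On a sulfonyl sulfur, 3-fluorophenyl in place of 3,5-dichlorophenyl gives a 1.1-fold higher number from compound 2 to compound 4 (0.05 log units; within the scatter) in this assay. Going by these compounds alone, all the earlier steps, on the aromatic carbon, lie beyond the scatter, so in these compounds that place moves the number, while this single pair shows no such movement for the group on the sulfonyl sulfur.

On these data alone, whether this holds with 2-fluorophenyl or 3-fluorophenyl on the aromatic carbon remains open, as does the effect of an amine or a carboxylic acid in place of 3-fluorophenyl on a sulfonyl sulfur. No supporting data bear on why this step is so small.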